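This account rests on a few compounds, and the source may have more. Where it says the series, first, only, none or still open, it means among the compounds named here.

In a functional assay on A549 cells (Homo sapiens) for inhibition, read by MTT assay, with a stated time of 72 h (on this read-out lower numbers stand for stronger inhibition and higher numbers for weaker inhibition), compound 1 `CCc1oc([C@H](C)/C=C(\C)[C@H](OC(C)=O)[C@H](C)[C@@H](OC(=O)CC(C)C)[C@@H](C)c2oc([C@@H](C)[C@H](CC)OC(C)=O)c(C)c(=O)c2C)c(C)c(=O)c1C` gives 28000 nM, and compound 3 `CCC(=O)[C@H](C)c1oc([C@H](C)[C@@H]2O[C@](O)([C@@H](C)c3oc(CC)c(C)c(=O)c3C)[C@@H](C)[C@@H](OC(=O)CC(C)C)[C@@H]2C)c(C)c(=O)c1C` gives 26000 nM, within the scatter of the former, while compound 2 `CCC(=O)O[C@@H](/C(C)=C/[C@@H](C)c1oc(CC)c(C)c(=O)c1C)[C@H](C)[C@@H](OC(=O)CC(C)C)[C@@H](C)c1oc([C@@H](C)[C@H](CC)OC(C)=O)c(C)c(=O)c1C` gives 3000 nM. Compound 4 `CCc1oc([C@H](C)/C=C(\C)[C@H](OC(C)=O)[C@H](C)[C@@H](OC(=O)CC(C)C)[C@@H](C)c2oc([C@@H](C)[C@@H](O)CC)c(C)c(=O)c2C)c(C)c(=O)c1C` carries one change relative to compound 1: hydrogen in place of acetyl on an oxygen on a saturated carbon. Acetoxy thus becomes hydroxy. Within the data shown here, only one measured step bears on this, and only loosely: a 9.3-fold lower number from compound 1 to compound 2 (0.97 log units; beyond the scatter), a modest step from a different change, methyl in place of hydrogen on a saturated chain carbon bound to a carbonyl carbon. It fixes no direction for the loss of acetyl, so no shift beyond the scatter is expected in this assay, though one of similar size remains possible. The expected change is a 1.1-fold lower number from compound 1 to compound 4 (0.05 log units; within the scatter). Compound 4 is estimated at 25000 nM, with a range of 8000 nM to 70000 nM.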

Compound 4, half-maximal inhibitory concentration: 15000 nM
Estimate against measurement, compound 4: 1.7-fold (0.22 log units) above, within the range that was stated.
By their numbers in this assay, from the lowest: compound 2; then compounds 4, 3 and 1 (each within the scatter of the next).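

With acetoxy becoming hydroxy, this assay gives a 1.9-fold lower number from compound 1 to compound 4 (0.27 log units; within the scatter), so at this oxygen on a saturated carbon, the loss of acetyl produces no shift that can be told from the scatter. The earlier compounds shown here gave no reading at this position, and this step now provides one. No measured evidence bears on the reason for this result.

Going by these compounds, whether an amine or a methoxy group here would move the number beyond the scatter stays open. So does whether the same loss of acetyl would behave alike in compound 2.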